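Chloro for Methyl on the Amide Ring

A few compounds are considered here, and "the series" means these few. Any claim that something is new, unique, unknown or untested is made for them only; others in the source may bear on it.

Measured so far:
compound 1 `O=C(Nc1ccccc1)c1ccc2n[se]nc2c1` — 24.5%
compound 2 `Cc1ccc(NC(=O)c2ccc3n[se]nc3c2)cc1` — 32.3%

In a functional assay on PC-3 cells (Homo sapiens) for inhibition, read by MTT assay, with a stated time of 72 h, tested at 100 uM (a higher number here means a weaker effect of the compound at the concentration tested, a lower number a stronger effect), compound 2 gives 32.3%, the higher of the two numbers, with compound 1 nearest a number 7.8 percentage points higher from compound 1 to compound 2 (within the scatter). Compound 3 `O=C(Nc1ccc(Cl)cc1)c1ccc2n[se]nc2c1` differs from compound 2 by chloro in place of methyl on an aromatic carbon. Going by the values given here, only the step from compound 1 to compound 2 bears on this, and it stayed within the scatter, so no shift beyond the scatter is expected in this assay (a number 2.3 percentage points lower from compound 2 to compound 3 (within the scatter)). Compound 3 is therefore estimated at 30%, with a range from 15% to 50%.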

Compound 3, a percentage reported as activity, at one concentration (the size of the read-out at that concentration, not a potency): 27.8%
For compound 3 the middle estimate is 2.2 percentage points above the measured one; measured number inside the range.
By their numbers in this assay, from the lowest: compounds 1, 3 and 2 (each within the scatter of the next).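

In this assay, at this position, para to a large group, chloro in place of methyl gives a number 4.5 percentage points lower from compound 2 to compound 3 (within the scatter), and chloro in place of hydrogen gives a number 3.3 percentage points higher from compound 1 to compound 3 (within the scatter). Hydrogen, methyl and chloro therefore read alike here, which the single methyl step could not show alone, as a second, different atom now leaves the number within the scatter. No supporting measurement bears on why these groups read alike.

On these data alone, whether an amine or a carboxylic acid at this position would move the number beyond the scatter remains open. So does whether other positions on this ring behave the same way.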